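The compounds below may be only part of what the source reports. "The series", "measured", "known", "first", "only" and "open" are said of these compounds alone.

Series notes. The shared core carries a 4-aryl substituent on the imidazopyridine; compound 1 `CC#CC(CC(=O)O)c1ccc(OCc2ccc3nc(-c4ccccc4C)cn3c2)cc1` bears 2-methylphenyl there, compound 2 `CC#CC(CC(=O)O)c1ccc(OCc2ccc3nc(-c4ccc(F)cc4F)cn3c2)cc1` 2,4-difluorophenyl. In an assay on isolated protein for agonist activity at Free fatty acid receptor 1 (Homo sapiens) (on this read-out higher numbers stand for an effect only at larger amounts of compound and lower numbers for an effect already at smaller amounts), compound 1 gives 389 nM and compound 2 gives 825 nM. Among the measured compounds shown here, compound 2 stands with the highest of the two numbers so far: the only step measured, a 2.1-fold higher number from compound 1 to compound 2 (0.33 log units; beyond the scatter), separates it from compound 1 and lies beyond the scatter.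

Compound 3 `CC#CC(CC(=O)O)c1ccc(OCc2ccc3nc(-c4ccccc4F)cn3c2)cc1` follows from compound 2 by hydrogen in place of fluoro on an aromatic carbon. For the measured compounds named here, the one measured step bears on it only indirectly, since it exchanged the whole aryl substitution pattern rather than removing a single fluoro; its size, a 2.1-fold higher number from compound 1 to compound 2 (0.33 log units; beyond the scatter), sets a scale of modest steps for this position. The change to compound 3 is a smaller one, and it moves the aryl group back part-way toward that of compound 1. A step in this assay of a 1.5-fold lower number from compound 2 to compound 3 (0.18 log units; within the scatter) is therefore expected, toward a lower number, possibly no further than the scatter. Compound 3 is estimated at 550 nM, within 250 nM to 1200 nM.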

Compound 3, half-maximal effective concentration: 583 nM
The estimate for compound 3 lay 1.1-fold (0.03 log units) below the measured number; the measured number falls inside the stated range.
By their numbers in this assay, from the lowest: compounds 1, 3 and 2 (each within the scatter of the next, the first and the last beyond it).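

Going from 2,4-difluorophenyl to 2-fluorophenyl gives a 1.4-fold lower number from compound 2 to compound 3 (0.15 log units; within the scatter) in this assay, so this read-out does not separate fluoro from hydrogen at the place meta to a fluoro group and para to a large group, and fluoro in place of methyl on an aromatic carbon, at a 1.5-fold higher number from compound 1 to compound 3 (0.18 log units; within the scatter), likewise stays unresolved. Among the compounds shown here, compound 3 therefore sits within the scatter of both other compounds, and the only step beyond the scatter remains a 2.1-fold higher number from compound 1 to compound 2 (0.33 log units; beyond the scatter), which changes the aryl substitution in more than one place and which neither single change accounts for on its own. No measurement at hand offers an explanation for any of these steps.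

The compounds shown leave open how 2-fluorophenyl compares with an unsubstituted phenyl group, which would show whether the remaining fluoro contributes anything measurable. They also leave open whether a clearly larger step appears at this position with a group other than fluoro or methyl, such as methoxy, chloro or an amine.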